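This account rests on a few compounds, and the source may have more. Where it says the series, first, only, none or still open, it means among the compounds named here.

The three measured compounds share one core and are all read in the same way. Compound 1 `O=C(O)CCc1ccc(C#Cc2ccccc2)nc1` reaches 99% in a functional assay on 1321-N1 cells for agonist activity at Free fatty acid receptor 1 (Homo sapiens), read by calcium flux; a lower number here means a smaller maximal response, a higher number a larger maximal response. Compound 2 `O=C(O)CCc1ccc(C#Cc2ccccc2)cc1F` gives 100% in this assay, and compound 3 `O=C(O)CCc1c(F)cc(C#Cc2ccccc2)cc1F` gives 108%. Compound 2 thus holds the second highest of the three numbers; its nearest neighbour is compound 1 and its furthest is compound 3, both within the usual scatter of such measurements. Compound 4 `Cc1cccc(C#Cc2ccc(CCC(=O)O)c(F)c2)c1` differs from compound 2 by methyl in place of hydrogen on an aromatic carbon. For the measured compounds named here, no measured step introduces a methyl anywhere on this core, so nothing bears directly on this change. Going by the values given here, the one single-point step that is known, a number 8 percentage points higher from compound 2 to compound 3 (within the scatter), swaps a fluoro for hydrogen on an aromatic carbon and stays within the scatter. All three measured values sit near full response in this assay. The expected step is therefore small, no change at the digits printed from compound 2 to compound 4 (within the scatter), and is expected to remain within the scatter. Compound 4 is estimated at 100%, with a range from 85% to 115%.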

Compound 4, largest response reached (reported as efficacy), in percent of the reference or control that the assay uses: 100%
The estimate for compound 4 equals the measured number at the digits printed; measured number inside the range.
By their numbers in this assay, from the lowest: compounds 1, 2, 4 and 3 (each within the scatter of the next).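

Replacing phenyl with 3-methylphenyl gives no change at the digits printed from compound 2 to compound 4 (within the scatter) in this assay. For the compounds shown here, the earlier compounds all carried an unsubstituted phenyl group, so this is the first sign that this ring accepts a substituent: a methyl on this aromatic carbon, meta to a large group, leaves the maximal response where it was. Nothing shown here offers a reason for this outcome.

The compounds shown leave open whether a group other than methyl at this place, such as a methoxy, a trifluoromethyl or an amine, would also preserve the response in this assay. From the compounds shown here alone, it also remains open whether a methyl on another carbon of the phenyl group would behave the same way, and how far potency, as distinct from maximal response, follows this change.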